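The source may hold more compounds than are shown below. What is called first, only, known or untested is meant among the compounds shown, and "the series" means these compounds.

Of the compounds shown here, three that share one core have been measured in a functional assay on HepG2 cells (Homo sapiens) for cytotoxicity, read by MTT assay, with a stated time of 72 h; on this read-out higher numbers stand for weaker inhibition and lower numbers for stronger inhibition. Compound 1 `Brc1ccccc1Nc1nc2cccnc2[se]1` gives 74200 nM. Compound 2 `Cc1ccccc1Nc1nc2cccnc2[se]1` gives 507000 nM, and compound 3 `Cc1ccc(Nc2nc3cccnc3[se]2)cc1` gives 235000 nM. On these numbers compound 2 stands highest of the three: compound 3 shows a lower number, and compound 1 a lower one still. Among the compounds with values here, only one pair among them differs in a single place, and that pair runs from compound 1 to compound 2, with a methyl taking the place of a bromo on an aromatic carbon; the number changed by a 6.8-fold higher number from compound 1 to compound 2 (0.83 log units; beyond the scatter).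

Compound 4 `Clc1ccccc1Nc1nc2cccnc2[se]1` has not yet been measured in this assay. It differs from compound 2 in one place: chloro in place of methyl on an aromatic carbon, on an aromatic carbon of a six-membered aromatic ring of carbon only, ortho to a large group. Within the data shown here, the step from compound 1 to compound 2 is the only measured step that bears on this change, and it went in the opposite direction, halogen to methyl, at the same place. Returning to a halogen, chloro, is therefore expected to lower the number from compound 2 to compound 4 by a step of modest size, estimated as a 3.9-fold lower number from compound 2 to compound 4 (0.59 log units; beyond the scatter). Compound 4 is expected to give about 130000 nM in this assay, within a range from 45000 nM to 380000 nM.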

Compound 4, half-maximal inhibitory concentration: 181000 nM
Beside the measured number, compound 4's estimate is 1.4-fold (0.14 log units) below it; measured number inside the range.
By their numbers in this assay, from the lowest: compound 1; then compounds 4 and 3 (each within the scatter of the next); then compound 2.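

In this assay, the lower number seen with bromo at this aromatic carbon, ortho to a large group, is not confined to bromo: chloro in place of methyl also lowers it, with a 2.8-fold lower number from compound 2 to compound 4 (0.45 log units; beyond the scatter). The two halogens are not interchangeable here, however, as the change from bromo to chloro gives a 2.4-fold higher number from compound 1 to compound 4 (0.39 log units; beyond the scatter), so the three groups at this place fall in a graded order, with bromo lowest, chloro in the middle and methyl highest, and each step lies beyond the scatter. This order rests on compound 1, compound 4 and compound 2 alone, and nothing available explains why these groups rank in this way.

What the compounds shown leave open is whether the order extends to other groups at this place, such as fluoro, methoxy or an amine, and whether any of them would fall outside the span set by bromo and methyl. As far as these compounds go, it is also open whether chloro or bromo would change the number in the same way at the place held by the methyl of compound 3.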